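The source may hold more compounds than are shown below. What is called first, only, known or untested is meant among the compounds shown, and "the series" means these compounds.

Measured compounds:

Compound 1, `C=C1CCCC(C)(C)[C@H]1Cc1c(OC)cc2oc(-c3ccc(O)c(O)c3)c(OC)c(=O)c2c1O`, in a functional assay on BV-2 cells (Mus musculus) for inhibition, read by Griess assay, with a stated time of 24 h (on this read-out lower numbers stand for stronger inhibition and higher numbers for weaker inhibition), gives 6700 nM.

Compound 2, `C=C1CCCC(C)(C)[C@H]1Cc1c(O)cc2oc(-c3ccc(O)c(O)c3)cc(=O)c2c1O`, in this assay gives 6500 nM.

These two values lie within the scatter of each other, so compound 2 stands level with compound 1 on the numbers shown; neither can be called the stronger inhibitor.

Compound 3, `C=C1CCCC(C)(C)[C@H]1Cc1c(OC)cc2oc(-c3ccc(O)c(O)c3)cc(=O)c2c1O`, has not yet been measured. Its structure differs from compound 2 in one place: methyl in place of hydrogen on an oxygen on an aromatic ring. Compound 1 carries the same methyl on that oxygen, together with a further methoxy group elsewhere on the shared core, and in this assay compound 1 gives 6700 nM, a number that sits within the scatter of compound 2. For the measured compounds named here, no step between measured compounds isolates this single change. The expectation for compound 3 therefore rests on the closeness of compound 1 and compound 2: the step in this assay from compound 2 to compound 3 is expected to be a 1.0-fold higher number from compound 2 to compound 3 (0.01 log units; within the scatter), that is, none beyond the scatter. Compound 3 is estimated at 6600 nM in this assay, with a range from 3000 nM to 14000 nM.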

Compound 3, half-maximal inhibitory concentration: 8100 nM
The estimate for compound 3 lay 1.2-fold (0.09 log units) below the measured number, and the stated range covers the measured number.
By their numbers in this assay, from the lowest: compounds 2, 1 and 3 (each within the scatter of the next).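

In this assay, the change from hydroxy to methoxy on an oxygen on an aromatic ring can now be read on its own, as a 1.2-fold higher number from compound 2 to compound 3 (0.10 log units; within the scatter) for methyl in place of hydrogen. On this read-out, then, the hydrogen on that oxygen can be replaced by methyl without taking the number beyond the scatter. The second single change, hydrogen in place of methoxy on an aromatic carbon, reads as a 1.2-fold higher number from compound 1 to compound 3 (0.08 log units; within the scatter) and shows that this further methoxy group on the shared core also leaves the number within the scatter, while no measurement shown offers an explanation for either step.

Going by these compounds, both steps involve only a hydrogen and a small methyl or methoxy group, so it remains open whether a longer chain such as butoxy on the same oxygen, or an amine in place of the hydroxy group, would give a number beyond the scatter. On these data alone, it is also open whether these two changes would stay within the scatter on a core that carries different groups elsewhere, since all three compounds share the rest of their structure.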